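The source may hold more compounds than are shown below. What is called first, only, known or untested is meant among the compounds shown, and "the series" means these compounds.

In a functional assay on V79-379A cells (Cricetulus griseus) for cytotoxicity, read by MTT assay, in the presence of a further agent that is not named here (a higher number here means a weaker inhibitor, a lower number a stronger inhibitor), compound 1 (`COC1=CC(=O)c2c(c(COC(=O)c3ccccc3)c(C)n2C)C1=O`) gives 16000 nM and compound 2 (`COC1=CC(=O)c2c(c(COc3ccccc3)c(C)n2C)C1=O`) gives 12000 nM as its value, so compound 2 stands level with compound 1 within the scatter. Compound 3 (`COC1=CC(=O)c2c(c(COc3cccc(NC(C)=O)c3)c(C)n2C)C1=O`) differs from compound 2 by one change: acetamido in place of hydrogen on an aromatic carbon. For the measured compounds named here, the one measured step (a 1.3-fold lower number from compound 1 to compound 2 (0.12 log units; within the scatter)) put phenyl in place of benzoyl and stayed within the scatter, but no measured compound carries acetamido, so it offers only weak guidance. In this assay no shift beyond the scatter is therefore expected, and the estimated step (a 1.2-fold lower number from compound 2 to compound 3 (0.08 log units; within the scatter)) is small. For compound 3 the expected value is 10000 nM (estimated range 4000 nM to 25000 nM).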

Compound 3, half-maximal inhibitory concentration: 3700 nM
Compound 3: middle estimate off by 2.7-fold (0.43 log units), on the high side, outside the stated range (below it).
By their numbers in this assay, from the lowest: compound 3; then compounds 2 and 1 (each within the scatter of the next).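

In this assay, the phenyl group proves responsive to substitution: acetamido in place of hydrogen, meta to a large group, gives a 3.2-fold lower number from compound 2 to compound 3 (0.51 log units; beyond the scatter), a modest step beyond the scatter. The earlier swap of phenyl for benzoyl had stayed within the scatter, so this is the first change shown to move the number beyond it. No supporting measurement accounts for this step.

On these data alone, it remains open whether a plain amine or a carboxylic acid in that place would give a similar step. Also open, as far as these compounds go, is whether acetamido would do the same on another aromatic carbon.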